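The source may report more compounds than this note shows. Statements on the series, on what has been measured and on what is new or still open speak of the compounds shown alone.

Measured compounds in a functional assay on DU-145 cells (Homo sapiens) for cytotoxicity, read by MTT assay, with a stated time of 48 h; on this read-out lower numbers stand for stronger inhibition and higher numbers for weaker inhibition:
compound 1 `CC(C)=CCC/C(C)=C/CC/C(C)=C/CC[C@@H]1[C@@]2(C)CC/C(=N\OCc3cn(-c4cccc(O)c4)nn3)C(C)(C)[C@@H]2CC[C@@]1(C)O`: 17500 nM
compound 2 `CC(C)=CCC/C(C)=C/CC/C(C)=C/CC[C@@H]1[C@@]2(C)CC/C(=N\OCc3cn(-c4ccc(F)c(Cl)c4)nn3)C(C)(C)[C@@H]2CC[C@@]1(C)O`: 26900 nM
compound 3 `CC(C)=CCC/C(C)=C/CC/C(C)=C/CC[C@@H]1[C@@]2(C)C/C(=C\c3ccc(OCc4cn(-c5cccc(O)c5)nn4)cc3)C(=O)C(C)(C)[C@@H]2CC[C@@]1(C)O`: 40600 nM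

The three measured compounds share a long chain and a bicyclic core; compound 1 and compound 2 carry a triazole on an oxime ether, while compound 3 carries its triazole on a phenyl ring joined to the core through a double bond. How the core of compound 3 differs from the core of compound 1 is not broken down here. Compound 3 gives the highest number of the three; against compound 2 the gap is within the scatter, against compound 1 it is beyond it.

Among the compounds with values here, the one change followed across the set is 3-chloro-4-fluorophenyl in place of 3-hydroxyphenyl on an aromatic nitrogen. Within the oxime series it gave a 1.5-fold higher number from compound 1 to compound 2 (0.19 log units; within the scatter), a step that does not separate the two compounds.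

Compound 4 `CC(C)=CCC/C(C)=C/CC/C(C)=C/CC[C@@H]1[C@@]2(C)C/C(=C\c3ccc(OCc4cn(-c5ccc(F)c(Cl)c5)nn4)cc3)C(=O)C(C)(C)[C@@H]2CC[C@@]1(C)O` is not yet measured. It differs from compound 3 by 3-chloro-4-fluorophenyl in place of 3-hydroxyphenyl on an aromatic nitrogen, the same change as that from compound 1 to compound 2, at the same place. Within the data shown here, compound 4 is expected to move by a 1.5-fold higher number from compound 3 to compound 4 (0.17 log units; within the scatter), resting on the one measured step, because compound 2 stands at 26900 nM after the same exchange. For compound 4 the estimate in this assay is 60000 nM, with a range from 30000 nM to 120000 nM, and since compound 3 already sits high, a result reported only as a limit would not be surprising.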

Compound 4, half-maximal inhibitory concentration: 28400 nM
The estimate for compound 4 lay 2.1-fold (0.32 log units) above the measured number; the measured number lies below the stated range.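

In this assay, 3-chloro-4-fluorophenyl in place of 3-hydroxyphenyl on an aromatic nitrogen gives a 1.4-fold lower number from compound 3 to compound 4 (0.16 log units; within the scatter), so this step does not separate the two compounds on the core of compound 3, just as the same exchange did not separate the pair on the core of compound 1. Set side by side, the two steps point in opposite directions on paper but cannot be told apart: the same change on two cores in this assay, a 1.5-fold higher number (0.19 log units; within the scatter) from compound 1 to compound 2 and a 1.4-fold lower number (0.16 log units; within the scatter) from compound 3 to compound 4, 2.2-fold (0.34 log units) apart, within the scatter of two such steps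

For this series, the exchange therefore carries from one core to the other as a step that stays within the scatter on both, but two pairs do not show that the exchange is without any effect, that the two cores respond identically, or that the same would hold on a further core.

The compounds shown hold only two aryl groups on the aromatic nitrogen, so it stays open whether a phenyl ring bearing an amine or a carboxylic acid, or a plain alkyl chain in place of the aryl group, would give a step beyond the scatter on either core. Also open, going by these compounds, is whether the long chain shared by all four compounds can be shortened, and whether any of these steps would look the same on cells other than those of this assay.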